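Swapping benzyl for cyanophenyl on a sulfonamide nitrogen

The source may report more compounds than this note shows. Statements on the series, on what has been measured and on what is new or still open speak of the compounds shown alone.

compound 1 `CC1(C)C=C(n2ccccc2=O)c2cc(S(=O)(=O)N=[N+]=[N-])ccc2O1`: 16.2 nM
compound 2 `CNS(=O)(=O)c1ccc2c(c1)C(n1ccccc1=O)=CC(C)(C)O2`: 17.8 nM
compound 3 `CC1(C)C=C(n2ccccc2=O)c2cc(S(=O)(=O)NCc3ccccc3)ccc2O1`: 525 nM

In a functional assay with Rattus norvegicus as the target (on this read-out higher numbers stand for an effect only at larger amounts of compound and lower numbers for an effect already at smaller amounts), compound 3 gives 525 nM, the highest of the three numbers. The steps of a 32-fold higher number from compound 1 to compound 3 (1.51 log units; beyond the scatter) and a 29-fold higher number from compound 2 to compound 3 (1.47 log units; beyond the scatter) both lie well beyond the scatter, while the step of a 1.1-fold higher number from compound 1 to compound 2 (0.04 log units; within the scatter) does not. Compound 4 `CC1(C)C=C(n2ccccc2=O)c2cc(S(=O)(=O)Nc3ccc(C#N)cc3)ccc2O1` differs from compound 3 in one place: 4-cyanophenyl in place of benzyl on a sulfonamide nitrogen. The step of a 29-fold higher number from compound 2 to compound 3 (1.47 log units; beyond the scatter) bears on this, since it shows how strongly a ring bound at this sulfonamide nitrogen raised the number; compound 4 keeps such a ring. Among the measured compounds shown here, no measured step exchanges one ring for another here, so the expected step is a 1.1-fold lower number from compound 3 to compound 4 (0.02 log units; within the scatter). Compound 4 is therefore estimated at 500 nM, within 150 nM to 1800 nM.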

Compound 4, half-maximal effective concentration: 263 nM
The estimate for compound 4 lay 1.9-fold (0.28 log units) above the measured number; the measured number falls inside the stated range.
By their numbers in this assay, from the lowest: compounds 1 and 2 (each within the scatter of the next); then compounds 4 and 3 (each within the scatter of the next).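

Exchanging benzyl for 4-cyanophenyl on the sulfonamide nitrogen leaves the two compounds within the scatter of each other in this assay (a 2.0-fold lower number from compound 3 to compound 4 (0.30 log units; within the scatter)). The high number is therefore not peculiar to benzyl, since this second ring-bearing group also stands far from the methylamino and azido compounds (a 15-fold higher number from compound 2 to compound 4 (1.17 log units; beyond the scatter); a 16-fold higher number from compound 1 to compound 4 (1.21 log units; beyond the scatter)). Nothing measured here explains these steps. Still open, on these data alone, is whether the nitrile matters, which plain phenyl on that nitrogen would test, and whether any larger group gives the same rise, which a butyl chain would test.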